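This account rests on a few compounds, and the source may have more. Where it says the series, first, only, none or still open, it means among the compounds named here.

Measured so far: compound 1 `O=C(O)[C@H]1NC[C@H](O)[C@H](O)[C@H]1O` with 21% in an assay for inhibition of alpha-N-acetylgalactosaminidase (Gallus gallus), tested at 1000 uM (a higher number here means more inhibition at the concentration tested (going by the name of the read-out), a lower number less inhibition), and compound 2 `O=C(O)[C@@H]1NCC=C[C@H]1O` with 3.2% in this assay. Compound 1 gives the higher of the two numbers, and its gap to compound 2 lies beyond the scatter. Compound 3 `O=C(O)[C@H]1NC[C@@H](O)[C@@H](O)[C@@H]1O` keeps every atom and bond of compound 1; the change is the two compounds have the same atoms and bonds and differ only in configuration as drawn: 3 of 4 stereo elements differ; a stereocentre at a saturated ring carbon is drawn S in compound 1 and R in compound 3; a stereocentre at a saturated ring carbon is drawn S in compound 1 and R in compound 3; a stereocentre at a saturated ring carbon is drawn S in compound 1 and R in compound 3. Among the compounds with values here, with no pair of measured compounds differing in this way, the direction is uncertain, but a change of this kind is expected to cost inhibition, so a step downward of a number 13 percentage points lower from compound 1 to compound 3 (beyond the scatter) is expected. For compound 3 the estimate is 8%, within 0% to 28%.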

Compound 3, a percentage reported as inhibition, at one concentration (the size of the read-out at that concentration, not a potency): 3.8%
Estimate against measurement, compound 3: 4.2 percentage points above; the measured number falls inside the stated range.
By their numbers in this assay, from the lowest: compounds 2 and 3 (each within the scatter of the next); then compound 1.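

Changing configuration alone, with no atom or bond added or lost, gives a number 17.2 percentage points lower from compound 1 to compound 3 (beyond the scatter) in this assay. Earlier, compounds 1 and 2 differed in more than one place, so no single change could be read. Here the step can be tied to configuration alone because of one fact: the fact that compounds 1 and 3 differ only in the configuration as drawn.

On these data alone, three stereocentres change together, so it remains open whether one of them alone accounts for the step. Also open, as far as these compounds go, is how a methyl ester in place of the carboxylic acid would affect inhibition.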